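Replacing Hydroxy by Methylamino on a Fused Core

This account rests on a few compounds, and the source may have more. Where it says the series, first, only, none or still open, it means among the compounds named here.

Compound 1, `O=c1[nH]c(=O)n(COCCO)cc1[N+](=O)[O-]`: in a functional assay (Oryctolagus cuniculus) for inhibition (a lower number here means a stronger inhibitor, a higher number a weaker inhibitor), compound 1 reaches only a limit, > 400 ug/mL.
Compound 2, `Nc1nc2c(nc(Br)n2COCCO)c(=O)[nH]1`: compound 2 gives 340 ug/mL.
Compound 3, `Nc1nc2c(nc(O)n2COCCO)c(=O)[nH]1`: compound 3 gives 48 ug/mL.

Compound 3 has the lowest of the two numbers shown; compound 1 sits at the limit of > 400 ug/mL in this assay, at which 1 of the 3 values shown sits. For the measured compounds named here, the one measured step, a 7.1-fold lower number from compound 2 to compound 3 (0.85 log units; beyond the scatter), is the only comparison available. Compound 4, `CNc1nc2c(=O)[nH]c(N)nc2n1COCCO`, differs from compound 3 as follows: methylamino in place of hydroxy on an aromatic carbon. Going by the values given here, no measured step exchanges hydroxy for methylamino, so no firm direction can be drawn from the data. The estimate for compound 4 is therefore a step of about a 1.7-fold higher number from compound 3 to compound 4 (0.22 log units; within the scatter) in this assay, expected to stay within the scatter, with an estimated value of 80 ug/mL in a range from 20 ug/mL to 320 ug/mL.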

Compound 4, concentration for 50% inhibition: > 400 ug/mL
Compound 4 was reported as a limit; the forecaster's own chance of this, stated with the estimate: 15%; middle value at least 5.0-fold (0.69 log units) away from the limit.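

At this aromatic carbon between two ring nitrogen atoms, the advantage seen with hydroxy does not carry over to methylamino, with the step being an at least 8.3-fold higher number from compound 3 to compound 4 (0.92 log units; beyond the scatter). Against bromo the step is only a floor, an at least 1.1-fold higher number from compound 2 to compound 4 (0.07 log units; that floor lies within the scatter), so it gives no order for compound 2 and compound 4. In this assay compound 4 gives only a limit, > 400 ug/mL, and that limit is now shared: the limit of > 400 ug/mL in this assay, at which 2 of the 4 values shown sit.

The compounds shown leave open whether an unsubstituted amine or a methoxy group on this carbon would come closer to compound 3 than methylamino does.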